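The source may hold more compounds than are shown below. What is called first, only, known or untested is meant among the compounds shown, and "the series" means these compounds.

Compound 1, `CC(C)Oc1cccc(-c2ccc(C(=O)N(Cc3cccc(OCCCCCC(=O)O)c3)C(C)C)cc2)c1`, gives in an ADME assay on Raji cells (Homo sapiens) for cytotoxicity, read by CellTiter-Glo and resazurin assay, with a stated time of 72 h (on this read-out lower numbers stand for an effect already at smaller amounts and higher numbers for an effect only at larger amounts of compound), only a limit, > 26000 nM.
Compound 2, `CC(C)N(Cc1cccc(OCCCCCC(=O)O)c1)C(=O)c1ccc(-c2ccc3c(c2)OCCO3)cc1`, gives in this assay only a limit, > 21900 nM.
Compound 3, `CC(C)N(Cc1cccc(OCCCCCC(=O)O)c1)C(=O)c1ccc(-c2cccc(S(C)(=O)=O)c2)cc1`, gives in this assay only a limit, > 26000 nM.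

All three measured values in this assay are limits of the assay and not numbers. Compound 2 therefore stands at a limit, the one described in the limit of > 21900 nM in this assay, at which 1 of the 3 values shown sits, while the other two measured compounds sit at the limit described in the limit of > 26000 nM in this assay, at which 2 of the 3 values shown sit. The steps a step that the two limits leave unreadable from compound 1 to compound 2, a step that the two limits leave unreadable from compound 1 to compound 3 and a step that the two limits leave unreadable from compound 2 to compound 3 cannot be read in size for this reason.

Compound 4, `CCOC(=O)CCCCCOc1cccc(CN(C(=O)c2ccc(-c3ccc4c(c3)OCCO4)cc2)C(C)C)c1`, differs from compound 2 by ethyl in place of hydrogen on an oxygen next to a carbonyl group. Among the compounds with values here, none of the measured steps touches this part of the structure, and none of them has a readable size, so the measured compounds give no ground for expecting a step in this assay beyond the scatter in either direction. Compound 4 is expected to sit at or near a limit again, with an estimate of 25000 nM, from 10000 nM to 60000 nM. The expected step is a step that the limit leaves unreadable from compound 2 to compound 4.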

Compound 4, half-maximal effective concentration: > 24400 nM
Compound 4: a limit, no number; the forecaster's own chance of this, stated with the estimate: 75%; the middle value lies beyond the limit too.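

In this assay compound 2 and compound 4 both give only limits and no numbers, and the step between them cannot be read in size. The compounds shown leave open at what concentration any of them would reach a half-maximal effect, and whether the carboxy and ethoxycarbonyl forms differ at all.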